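The source may report more compounds than this note shows. Statements on the series, on what has been measured and on what is new or still open speak of the compounds shown alone.

Going by the values given here, in a functional assay on NCI-H460 cells (Homo sapiens) for inhibition, read by MTT assay, with a stated time of 24 h, tested at 100 ug/mL (a lower number here means less inhibition of growth, a higher number more inhibition of growth at the concentration tested), compound 2 (`O=C(CCCCC(S)CCS)Nc1ccc([N+](=O)[O-])c(C(F)(F)F)c1`) gives 95.9% as the higher of the two numbers so far, and compound 1 (`O=C(CCCCC(S)CCS)Nc1ccc(Cl)cc1`) gives 40.9% as the lower, a gap beyond the scatter. Against compound 2, compound 3 (`O=C(CCCCC(S)CCS)Nc1ccc([N+](=O)[O-])cc1`) has hydrogen in place of trifluoromethyl on an aromatic carbon, ortho to a nitro group (hydrogen in place of trifluoromethyl on an aromatic carbon). Among the compounds with values here, no measured pair isolates this change, so the expectation rests on little. Compound 2 at 95.9% already sits close to the top of the read-out, which makes a fall more likely than a rise, and compound 1 at 40.9% serves only as a loose lower reference. In this assay a moderate fall beyond the scatter is expected, estimated as a number 25.9 percentage points lower from compound 2 to compound 3 (beyond the scatter) in size. For compound 3 the estimated value is 70% with an expected range (45% to 92%).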

Compound 3, percent growth inhibition at one concentration: 39.1%
Beside the measured number, compound 3's estimate is 30.9 percentage points above it; the measured number lies below the stated range.
By their numbers in this assay, from the lowest: compounds 3 and 1 (each within the scatter of the next); then compound 2.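

In this assay, hydrogen in place of trifluoromethyl on an aromatic carbon, ortho to a nitro group, gives a number 56.8 percentage points lower from compound 2 to compound 3 (beyond the scatter), so within this pair the high reading of compound 2 depends on the trifluoromethyl group and the nitro group alone does not sustain it. Nitro in place of chloro on an aromatic carbon gives a number 1.8 percentage points lower from compound 1 to compound 3 (within the scatter), so in this assay that exchange does not separate the two compounds when no trifluoromethyl group is present. No measured property of these compounds bears on the reason for the large step.

Open, as far as these compounds go, is whether a methyl group or a nitrile on the same carbon would match trifluoromethyl, and whether trifluoromethyl keeps the high reading with chloro in place of the nitro group. Also open, from the compounds shown here alone, is how a shorter chain between the amide carbonyl and the two thiol groups would read.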